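Adding an Amide Side Chain to Compound 2

The compounds below may be only part of what the source reports. "The series", "measured", "known", "first", "only" and "open" are said of these compounds alone.

Among the compounds with values here, in a functional assay on HeLa cells (Homo sapiens) for antiproliferative activity, read by CCK-8 assay, with a stated time of 72 h (on this read-out lower numbers stand for stronger inhibition of growth and higher numbers for weaker inhibition of growth), compound 2 `CC[C@@H]1C(=O)N(C)c2cnc(-n3ccc4ccccc43)nc2N1C1CCCC1` gives 33900 nM, the highest of the three numbers measured so far. Compound 4 `CC[C@@H]1C(=O)N(C)c2cnc(-n3ccc4cc(C(=O)NCC(C)C)ccc43)nc2N1C1CCCC1` alters it in one place: isobutylcarbamoyl in place of hydrogen on an aromatic carbon. In words, isobutylcarbamoyl stands in place of hydrogen on an aromatic carbon.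

Within the data shown here, no measured step shows this group being added directly. Two compounds with related amide side chains offer the nearest guide, although they also differ from compound 2 elsewhere. Compound 1 `CCC1C(=O)N(C)c2cnc(-n3ccc4cc(C(=O)NC(C)C)ccc43)nc2N1c1ccn(C)n1` gives 4350 nM and compound 3 `CCNC(=O)c1ccc2c(ccn2-c2ncc3c(n2)N(c2ccn(C)n2)C(CC)C(=O)N3C)c1` gives 11100 nM, and both numbers lie below that of compound 2. Among the measured compounds shown here, the one measured step within this side chain is modest: a 2.6-fold higher number from compound 1 to compound 3 (0.41 log units; beyond the scatter), with hydrogen in place of methyl on the chain.

A clear fall in the number is therefore expected, and the estimated step is an 11-fold lower number from compound 2 to compound 4 (1.05 log units; beyond the scatter). In this assay, compound 4 is estimated at 3000 nM, with an expected range from 500 nM to 15000 nM.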

Compound 4, concentration for 50% growth inhibition: 3280 nM
Beside the measured number, compound 4's estimate is 1.1-fold (0.04 log units) below it, within the range that was stated.
By their numbers in this assay, from the lowest: compounds 4 and 1 (each within the scatter of the next); then compound 3; then compound 2.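

With the rest of compound 2 left unchanged, the step in this assay is a 10-fold lower number from compound 2 to compound 4 (1.01 log units; beyond the scatter), and this isolates the effect of placing isobutylcarbamoyl on this aromatic carbon. Compounds 1 and 3 also carry amide side chains, but they differ from compound 2 in other places, so they could not show how much of their lower numbers belonged to the side chain alone. What lies behind the fall remains unexplained, as no supporting measurement bears on it.

As far as these compounds go, it remains open whether the fall depends on the amide link, the isobutyl part or both. A carboxylic acid or an amine on this same aromatic carbon, or a longer chain on the amide nitrogen, would help separate these possibilities.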